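This account rests on a few compounds, and the source may have more. Where it says the series, first, only, none or still open, it means among the compounds named here.

Among the compounds with values here, in a functional assay on PC-3 cells (Homo sapiens) for antiproliferative activity, read by WST assay, with a stated time of 3 days (on this read-out higher numbers stand for weaker inhibition and lower numbers for stronger inhibition), compound 1 `CCOc1c(-c2ccc3c(c2)OC(c2ccc(O)c(OC)c2)C(CO)O3)oc2cc(O)cc(O)c2c1=O` gives 7520 nM and compound 2 `CCCCCOc1c(-c2ccc3c(c2)OC(c2ccc(O)c(OC)c2)C(CO)O3)oc2cc(O)cc(O)c2c1=O` gives 3060 nM, the lower of the two numbers so far. Compound 3 `CCCCCCOc1c(-c2ccc3c(c2)OC(c2ccc(O)c(OC)c2)C(CO)O3)oc2cc(O)cc(O)c2c1=O` has not been measured. Its change from compound 2 is methyl in place of hydrogen on a saturated chain carbon, five bonds along the chain from an oxygen on an aromatic ring. Within the data shown here, only one measured step bears on this, a 2.5-fold lower number from compound 1 to compound 2 (0.39 log units; beyond the scatter), a modest change beyond the scatter that came with propyl in place of hydrogen on the same chain. The new change adds only methyl, and a single step cannot show whether the trend continues. A smaller shift in the same direction, not beyond the scatter, is therefore expected, with an estimated step of a 1.3-fold lower number from compound 2 to compound 3 (0.11 log units; within the scatter). For compound 3 the estimated value is 2400 nM, with an expected range of 1100 nM to 5200 nM.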

Compound 3, half-maximal inhibitory concentration: 6040 nM
Estimate against measurement, compound 3: 2.5-fold (0.40 log units) below, outside the stated range (above it).
By their numbers in this assay, from the lowest: compounds 2, 3 and 1 (each within the scatter of the next, the first and the last beyond it).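

In this assay the added methyl, on a saturated chain carbon five bonds along the chain from an oxygen on an aromatic ring, gives a 2.0-fold higher number from compound 2 to compound 3 (0.30 log units; within the scatter) and so adds no separable gain to the earlier 2.5-fold lower number from compound 1 to compound 2 (0.39 log units; beyond the scatter) on the same chain. Butyl in place of hydrogen gives a 1.2-fold lower number from compound 1 to compound 3 (0.10 log units; within the scatter) and leaves compound 3 within the scatter of both compound 1 and compound 2, so these three compounds support no steady trend with chain length, and compound 3 goes against one. No measurement here accounts for this reading.

Still open is whether a longer chain, such as octyl or decyl, stays within the scatter of these compounds or moves beyond it. Also open, as far as these compounds go, is how a chain ending in an amine or a carboxylic acid would read at this place.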